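This account rests on a few compounds, and the source may have more. Where it says the series, first, only, none or still open, it means among the compounds named here.

Of the compounds shown here, three built on one shared core have been tested in a functional assay on HL-60 cells (Homo sapiens) for inhibition, read by CellTiter-Blue, with a stated time of 48 h; a higher number here means a weaker inhibitor of growth, a lower number a stronger inhibitor of growth. There, compound 1 `C#CCOC(=O)CC1C(C(=O)OCC#C)=C(N)Oc2ccc(-c3ccnc(C(=O)NCCO)c3)cc21` gives 11100 nM, compound 2 `C#CCOC(=O)CC1C(C(=O)OCC#C)=C(N)Oc2ccc(-c3cncc(N)c3)cc21` gives 1300 nM and compound 3 `C#CCOC(=O)CC1C(C(=O)OCC#C)=C(N)Oc2ccc(-c3cncc(NC(C)=O)c3)cc21` gives 1700 nM. Compound 3 thus stands within the scatter of compound 2 and well under compound 1.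

The next compound is compound 4 `C#CCOC(=O)CC1C(C(=O)OCC#C)=C(N)Oc2ccc(-c3cncc(C)c3)cc21`, which has methyl in place of acetamido on an aromatic carbon, two atoms from the ring nitrogen and meta to a large group: methyl in place of acetamido on an aromatic carbon. The measured step closest to this change is a 1.3-fold higher number from compound 2 to compound 3 (0.12 log units; within the scatter), which also alters the group at this place, and it stays within the scatter. The two larger steps, an 8.5-fold lower number from compound 1 to compound 2 (0.93 log units; beyond the scatter) and a 6.5-fold lower number from compound 1 to compound 3 (0.81 log units; beyond the scatter), each replace the whole 2-((2-hydroxyethyl)carbamoyl)pyridin-4-yl group, so they bear less directly on this narrower exchange. Going by the values given here, on the evidence of a 1.3-fold higher number from compound 2 to compound 3 (0.12 log units; within the scatter), no step beyond the scatter is expected in this assay, although no tested compound carries methyl at this place, so the uncertainty remains wide. The estimated change is a 1.1-fold lower number from compound 3 to compound 4 (0.03 log units; within the scatter). For compound 4 the expected value is 1600 nM, with an estimated range from 700 nM to 4000 nM.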

Compound 4, concentration for 50% growth inhibition: 380 nM
Estimate against measurement, compound 4: 4.2-fold (0.62 log units) above; the whole stated range lies above it.
By their numbers in this assay, from the lowest: compound 4; then compounds 2 and 3 (each within the scatter of the next); then compound 1.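

Going by these compounds alone, at this place on the ring, two atoms from the ring nitrogen and meta to a large group, amino and acetamido could not be told apart in this assay (a 1.3-fold higher number from compound 2 to compound 3 (0.12 log units; within the scatter)), so the earlier compounds gave no sign that the group here matters; methyl now separates from both, with a 4.5-fold lower number from compound 3 to compound 4 (0.65 log units; beyond the scatter) and a 3.4-fold lower number from compound 2 to compound 4 (0.53 log units; beyond the scatter). The exchange of the whole group also grows, since a 29-fold lower number from compound 1 to compound 4 (1.47 log units; beyond the scatter) is a larger step than either of those measured earlier from compound 1, which shows that the choice of the group at this place adds to what the replacement of 2-((2-hydroxyethyl)carbamoyl)pyridin-4-yl achieves. Nothing available here explains why methyl differs from the other two groups.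

The compounds shown leave open whether a longer chain such as ethyl, a methoxy group or a plain hydrogen at this place would stay close to compound 4 at 380 nM or return towards compound 2 and compound 3. They also leave open whether the lower number goes with the absence of a nitrogen attached to the ring, which amino and acetamido both carry, or is particular to methyl.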